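The compounds below may be only part of what the source reports. "The series", "measured", "known", "first", "only" and "open" are said of these compounds alone.

Measured in a functional assay on PC-9 cells (Homo sapiens) for inhibition, read by MTT assay, with a stated time of 48 h, tested at 10 uM; on this read-out higher numbers stand for more inhibition at the one concentration tested (going by the name of the read-out) and lower numbers for less inhibition:
compound 1 `CCc1ccc(Nc2cc(NC(=O)Nc3cc(OC)cc(OC)c3)ncn2)cc1`: 78%
compound 2 `Cc1ccc(Nc2cc(NC(=O)Nc3c(Cl)cccc3Cl)ncn2)cc1C`: 92.1%
compound 3 `CC(C)(C)c1ccc(Nc2cc(NC(=O)Nc3c(Cl)cccc3Cl)ncn2)cc1`: 41.5%

Compound 1 stands second highest of the three numbers. Its nearest neighbour is compound 2, whose number lies higher by more than the usual scatter; the furthest is compound 3, whose number lies lower by more than the scatter. No two of these compounds differ in only one place, so no single step can be read among them; compounds 2 and 3 share a urea part that compound 1 lacks, and what they show is taken only as the spread of the series, not as a trend.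

Compound 4 `COc1cc(NC(=O)Nc2cc(Nc3ccc(Br)cc3OC)ncn2)cc(OC)c1` is next to be measured. It differs from compound 1 in one place:
4-bromo-2-methoxyphenyl in place of 4-ethylphenyl on a nitrogen on an aromatic ring
The shared core and the urea part of compound 1 are kept. With nothing in the series that isolates this change, a small downward step, within the scatter, is expected: a number 8 percentage points lower from compound 1 to compound 4 (within the scatter). The number expected for compound 4 is 70%, with a range from 40% to 90%. The estimate leans on compound 1 because compound 1 gives 78% with the same urea part in place.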

Compound 4, a percentage reported as inhibition, at one concentration (the size of the read-out at that concentration, not a potency): 83%
The estimate for compound 4 lay 13 percentage points below the measured number, within the range that was stated.
By their numbers in this assay, from the lowest: compound 3; then compounds 1, 4 and 2 (each within the scatter of the next, the first and the last beyond it).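

In this assay, 4-bromo-2-methoxyphenyl in place of 4-ethylphenyl on a nitrogen on an aromatic ring gives a number 5 percentage points higher from compound 1 to compound 4 (within the scatter). Among these compounds, this is the first single-place step, and it shows that, with the shared core and the urea part of compound 1 kept, this position can carry a ring with bromine and a methoxy group instead of ethyl without a change that stands clear of the scatter. No measurement here bears on the reason for this result.

The step swaps ethyl for bromine and adds the methoxy group at once, so the compounds shown cannot separate the two, and a phenyl ring carrying only the bromine or only the methoxy group would be needed for that. Also open, on these data alone, is how this position responds to a ring carrying an amine or a carboxylic acid.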